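Chloro Substitution on Two Related Isatin-Derived Cores

A few compounds are considered here, and "the series" means these few. Any claim that something is new, unique, unknown or untested is made for them only; others in the source may bear on it.

The measured compounds are:
compound 1, `CCN(CC)CN1C(=O)/C(=N\c2nc3ccc(C)cc3s2)c2ccccc21`, 63500 nM;
compound 2, `CCN(CC)CN1C(=O)/C(=N\c2nc3ccc(C)cc3s2)c2c(Cl)cccc21`, 27300 nM;
compound 3, `CN(C)CN1C(=O)C(=O)c2ccccc21`, 50200 nM.

All three were tested in a functional assay on MDA-MB-468 cells (Homo sapiens) for cytotoxicity, read by sulforhodamine B assay, with a stated time of 48 h; a lower number here means a stronger inhibitor of growth, a higher number a weaker inhibitor of growth. Compound 1 and compound 2 share a core and differ in one place: chloro in place of hydrogen on an aromatic carbon. This change gave a 2.3-fold lower number from compound 1 to compound 2 (0.37 log units; beyond the scatter). Compound 3 carries a different core; the difference between the core of compound 3 and the core of compound 1 is not broken down here. Its value in this assay lies within the usual scatter of both compound 1 and compound 2, so nothing is said here about its order relative to either of them.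

Compound 4, `CN(C)CN1C(=O)C(=O)c2c(Cl)cccc21`, has not yet been measured. It differs from compound 3 as follows: chloro in place of hydrogen on an aromatic carbon. The place of this change, on an aromatic carbon of a six-membered aromatic ring of carbon only, part of a fused system of two rings, ortho to a fused ring and meta to a fused ring, is described in the same words as for the step from compound 1 to compound 2, so this is the same change made on a second core. Among the measured compounds shown here, because the earlier instance gave a 2.3-fold lower number from compound 1 to compound 2 (0.37 log units; beyond the scatter), a step of similar size is expected here, tempered by the fact that only a single prior example exists and the core is different. The step from compound 3 to compound 4 is estimated as a 2.0-fold lower number from compound 3 to compound 4 (0.30 log units; within the scatter). Compound 4 is therefore expected to give about 25000 nM in this assay, with a likely range from 12000 nM to 60000 nM.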

Compound 4, concentration for 50% growth inhibition: 107000 nM
Compound 4: the middle estimate sits 4.3-fold (0.63 log units) below what was measured; measured number outside the range, above it.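

On the core of compound 3, chloro in place of hydrogen on an aromatic carbon gave a 2.1-fold higher number from compound 3 to compound 4 (0.33 log units; beyond the scatter) in this assay, so the change that had lowered the number on the core of compound 1 raised it here. Set side by side, the two instances run in opposite directions and the gap between them exceeds what scatter would allow: the same change on two cores in this assay, a 2.3-fold lower number (0.37 log units; beyond the scatter) from compound 1 to compound 2 and a 2.1-fold higher number (0.33 log units; beyond the scatter) from compound 3 to compound 4, 5.0-fold (0.70 log units) apart, beyond the scatter of two such steps. This shows that, in this assay and for these two cores, the result of this change on one core could not be carried over to the other, not even in direction, but it does not show what in the cores lies behind the difference, and with one pair on each core it gives no general rule for the series.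

The compounds shown leave open whether another group at this place, such as fluoro, bromo or methoxy, would follow the step seen on the core of compound 1 or the one seen on the core of compound 3. They also leave open whether the chloro step would hold its direction on either core if a morpholine took the place of the amine that each core carries.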